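Difluoro chalcone-pyrazole: a step from the amino analogue

A few compounds are considered here, and "the series" means these few. Any claim that something is new, unique, unknown or untested is made for them only; others in the source may bear on it.

Measured compounds in a functional assay on NCI-H522 cells (Homo sapiens) for cytotoxicity, read by sulforhodamine B assay, with a stated time of 48 h, tested at 0.1 uM; a higher number here means a weaker effect of the compound at the concentration tested, a lower number a stronger effect:
- compound 1 `COc1cc(-c2cc(/C=C/C(=O)c3ccc(N)cc3)[nH]n2)cc(OC)c1OC` gives 92%
- compound 2 `COc1cc(-c2cc(/C=C/C(=O)c3ccc(Cl)c(Cl)c3)[nH]n2)cc(OC)c1OC` gives 89%
- compound 3 `COc1ccc(C(=O)/C=C/c2cc(-c3cc(OC)c(OC)c(OC)c3)n[nH]2)cc1` gives 87%

All three share the same core, a trimethoxyphenyl group joined through a pyrazole to an unsaturated ketone, and differ only in the aryl group on the carbonyl carbon. The numbers lie close together: the step of a number 3 percentage points lower from compound 1 to compound 2 (within the scatter) and the step of a number 5 percentage points lower from compound 1 to compound 3 (within the scatter) are both within the scatter, as is the step of a number 2 percentage points lower from compound 2 to compound 3 (within the scatter), so none of the three can be set apart from the others at this concentration.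

Compound 4 `COc1cc(-c2cc(/C=C/C(=O)c3ccc(F)c(F)c3)[nH]n2)cc(OC)c1OC` has not yet been measured. Relative to compound 1 the change is 3,4-difluorophenyl in place of 4-aminophenyl on a carbonyl carbon. For the measured compounds named here, the one measured step that bears directly on it is the step of a number 3 percentage points lower from compound 1 to compound 2 (within the scatter), where a dihalogenated phenyl also replaced the aminophenyl; the step of a number 2 percentage points lower from compound 2 to compound 3 (within the scatter) shows that swapping that dihalogenated phenyl for another aryl group again changed little. No step beyond the scatter is therefore expected in this assay.

Compound 4 is expected to give about 89%, with a range from 80% to 98%, which is an estimated step of a number 3 percentage points lower from compound 1 to compound 4 (within the scatter).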

Compound 4, a percentage reported as activity, at one concentration (the size of the read-out at that concentration, not a potency): 99%
For compound 4 the middle estimate is 10 percentage points below the measured one; the measured number lies above the stated range.
By their numbers in this assay, from the lowest: compounds 3, 2, 1 and 4 (each within the scatter of the next, the first and the last beyond it).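

In this assay, for the compounds shown here, the 3,4-difluorophenyl group provides the first step at this carbonyl carbon that lies beyond the scatter (a number 12 percentage points higher from compound 3 to compound 4 (beyond the scatter)), so the choice of aryl group here can shift the read-out, though only modestly. The other two steps (a number 7 percentage points higher from compound 1 to compound 4 (within the scatter); a number 10 percentage points higher from compound 2 to compound 4 (within the scatter)) stay within the scatter, so compound 4 cannot be set apart from the aminophenyl or dichlorophenyl compounds, and only its pairing with the 4-methoxyphenyl compound separates. No measurement shown here explains why that one pair separates.

As far as these compounds go, it remains open what a pyridyl ring or a cyclohexyl ring would do on this carbonyl carbon, and whether a single fluorine on the phenyl ring would behave like the two in compound 4. From the compounds shown here alone, with every compound read at one low concentration, it also remains open whether the separation between the 3,4-difluorophenyl and 4-methoxyphenyl groups would hold at higher concentrations.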